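Swapping a Benzyl Ester for a Furan Ketone

The compounds below may be only part of what the source reports. "The series", "measured", "known", "first", "only" and "open" are said of these compounds alone.

Of the compounds shown here, two sharing one core have been tested in a functional assay on OE19 cells (Homo sapiens) for cytotoxicity, read by MTT assay, with a stated time of 48 h; on this read-out lower numbers stand for stronger inhibition and higher numbers for weaker inhibition. Compound 1 `CC1(C)S[C@@H]2/C(=C\C(=O)c3cc(F)cc(F)c3)C(=O)N2[C@H]1C(=O)OC(c1ccccc1)c1ccccc1` gives 17600 nM in this assay, and compound 2 `CC1(C)S[C@@H]2/C(=C\C(=O)OCc3ccccc3)C(=O)N2[C@H]1C(=O)OC(c1ccccc1)c1ccccc1` gives 8200 nM. Among the measured compounds shown here, the single measured step, a 2.1-fold lower number from compound 1 to compound 2 (0.33 log units; beyond the scatter), leaves compound 2 with the lowest of the two numbers, while compound 1 sits higher.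

The next compound, compound 3 `CC1(C)S[C@@H]2/C(=C\C(=O)c3ccco3)C(=O)N2[C@H]1C(=O)OC(c1ccccc1)c1ccccc1`, differs from compound 2 in one place: furan-2-yl in place of benzyloxy on a carbonyl carbon. This change removes the benzyloxy group that set compound 2 apart from compound 1 and again places an aromatic ring on the carbonyl carbon, as in compound 1. For the measured compounds named here, the only step that bears on it is a 2.1-fold lower number from compound 1 to compound 2 (0.33 log units; beyond the scatter), of modest size; read in reverse, it hints that a ring on the carbonyl carbon may move the number back upward, though a furan-2-yl ring is not a 3,5-difluorophenyl ring and no direct test of it exists here. The expected step is therefore a 1.7-fold higher number from compound 2 to compound 3 (0.23 log units; within the scatter), toward a somewhat higher number. Compound 3 is thus estimated at 14000 nM, within a range from 5000 nM to 40000 nM.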

Compound 3, half-maximal inhibitory concentration: 54300 nM
For compound 3 the middle estimate is 3.9-fold (0.59 log units) below the measured one, outside the stated range (above it).
By their numbers in this assay, from the lowest: compound 2; then compound 1; then compound 3.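

In this assay, among the compounds shown here, the group on this carbonyl carbon has a larger effect than the first two compounds could show: replacing benzyloxy with furan-2-yl gives the widest step so far (a 6.6-fold higher number from compound 2 to compound 3 (0.82 log units; beyond the scatter)). Having an aromatic ring on the carbonyl carbon does not settle the number either, as exchanging 3,5-difluorophenyl for furan-2-yl also moves it beyond the scatter (a 3.1-fold higher number from compound 1 to compound 3 (0.49 log units; beyond the scatter)), so these two rings are not interchangeable at this place. No measurement shown here accounts for compound 3 giving the highest number of the three.

The compounds shown leave open whether the difference between the two rings comes with the change from a six-membered to a five-membered ring, with the ring oxygen, or with the two fluorines of compound 1, and an unsubstituted phenyl or a thiophen-2-yl ring on the same carbonyl carbon would help to separate these. They also leave open whether the lowest number, that of compound 2, depends on its benzene ring or on the oxygen joining it to the carbonyl, which a methoxy group or a longer chain such as 2-phenylethyl could test.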